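Hydroxamate series: trifluoromethyl on the pendant phenyl

The source may hold more compounds than are shown below. What is called first, only, known or untested is meant among the compounds shown, and "the series" means these compounds.

Measured so far in a functional assay on HCT-116 cells (Homo sapiens) for inhibition, read by MTT assay, with a stated time of 72 h; a lower number here means a stronger inhibitor, a higher number a weaker inhibitor:

Compound 1, `COc1cc2c(Oc3ccc(NC(=O)c4nn(-c5ccccc5)cc(C)c4=O)cc3)ccnc2cc1OCCCCCCC(=O)NO`: 150 nM
Compound 2, `COc1cc2c(Oc3ccc(NC(=O)c4nn(-c5ccccc5F)cc(C)c4=O)cc3F)ccnc2cc1OCCCCCC(=O)NO`: 590 nM
Compound 3, `COc1cc2c(Oc3ccc(NC(=O)c4nn(-c5ccccc5C(F)(F)F)ccc4=O)cc3)ccnc2cc1OCC(=O)NO`: 9500 nM

Compound 1 gives the lowest of the three numbers in this assay; compound 2 sits nearest, beyond the scatter, and compound 3 is furthest, also beyond the scatter. Compound 1 is therefore the most potent of the three measured compounds. Compounds 2 and 3 each differ from compound 1 in several places at once, so none of the three pairs isolates a single change, and none of them reports on the change considered next.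

Compound 4, `COc1cc2c(Oc3ccc(NC(=O)c4nn(-c5cccc(C(F)(F)F)c5)cc(C)c4=O)cc3)ccnc2cc1OCCCCCCC(=O)NO`, differs from compound 1 in one place: trifluoromethyl in place of hydrogen on an aromatic carbon. Going by the values given here, no measured pair shows this change on the shared core, so the expectation rests on compound 1 alone. In this assay a small step is expected, a 1.7-fold higher number from compound 1 to compound 4 (0.22 log units; within the scatter), towards a somewhat weaker inhibitor, close to or just beyond the scatter. Compound 4 is estimated at 250 nM, within a range from 100 nM to 700 nM.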

Compound 4, half-maximal inhibitory concentration: 590 nM
Beside the measured number, compound 4's estimate is 2.4-fold (0.37 log units) below it; the range from low to high includes it.
By their numbers in this assay, from the lowest: compound 1; then compounds 2 and 4 (each within the scatter of the next); then compound 3.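

Going by these compounds alone, the phenyl to 3-(trifluoromethyl)phenyl change gives the first step that isolates a single place, and in this assay it reads as a 3.9-fold higher number from compound 1 to compound 4 (0.59 log units; beyond the scatter) on the core of compound 1. Compounds 2 and 3 could not show this, since each differs from compound 1 in several places at once. At this aromatic carbon, meta to a large group, trifluoromethyl therefore costs a modest but real amount of potency and does not abolish activity. Nothing measured here explains the step.

The compounds shown leave open whether this loss is specific to trifluoromethyl, as a chlorine atom, a nitrile or an amine at the same carbon would test. Also open, on these data alone, is whether the same step holds at the other carbons of this phenyl ring, or on a core with a shorter hydroxamate chain.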